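Trading a Cyclohexylphenyl for a Dimethylphenyl Group

The compounds below may be only part of what the source reports. "The series", "measured", "known", "first", "only" and "open" are said of these compounds alone.

Compound 3 `CC#CC(CC(=O)O)c1ccc(OCc2ccn3cc(-c4ccc(C5CCCCC5)cc4)nc3c2)cc1` gives 559 nM in an assay on isolated protein for agonist activity at Free fatty acid receptor 1 (Homo sapiens); on this read-out lower numbers stand for an effect already at smaller amounts and higher numbers for an effect only at larger amounts of compound. Among the three compounds measured so far it holds the second highest number: compound 1 `CC#CC(CC(=O)O)c1ccc(OCc2ccc3nc(-c4ccc(CC)cc4)cn3c2)cc1` gives 496 nM, within the scatter of compound 3, while compound 2 `CC#CC(CC(=O)O)c1ccc(OCc2ccn3cc(-c4ccccc4)nc3c2)cc1` gives 1260 nM, a gap beyond the scatter. Among the compounds with values here, the only single-point step in the set is a 2.3-fold lower number from compound 2 to compound 3 (0.35 log units; beyond the scatter). Compound 4 `CC#CC(CC(=O)O)c1ccc(OCc2ccn3cc(-c4ccc(C)cc4C)nc3c2)cc1` differs from compound 3 by 2,4-dimethylphenyl in place of 4-cyclohexylphenyl on an aromatic carbon. Within the data shown here, this change removes the cyclohexyl that the one measured step had introduced and adds two methyl groups, for which no step has been measured. Compound 4 is therefore expected to give 800 nM, within a range of 400 nM to 1600 nM. The expected step is a 1.4-fold higher number from compound 3 to compound 4 (0.16 log units; within the scatter), a modest rise in the number.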

Compound 4, half-maximal effective concentration: 503 nM
Compound 4: the middle estimate sits 1.6-fold (0.20 log units) above what was measured; the range from low to high includes it.
By their numbers in this assay, from the lowest: compounds 1, 4 and 3 (each within the scatter of the next); then compound 2.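

At this place, on the five-membered aromatic ring next to the ring nitrogen, 2,4-dimethylphenyl and 4-cyclohexylphenyl cannot be told apart in this assay, with a 1.1-fold lower number from compound 3 to compound 4 (0.05 log units; within the scatter) as the swap. Set against the plain phenyl, 2,4-dimethylphenyl gives a 2.5-fold lower number from compound 2 to compound 4 (0.40 log units; beyond the scatter), so cyclohexyl is not the only substitution on this phenyl that moves the number beyond the scatter. Nothing available explains why these two groups read alike. The compounds shown leave open whether a single methyl would be enough, and how an amine or a methoxy group on this phenyl would read.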